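Sulfonamide aryl swap in a bromotriazole thioether series

The source may hold more compounds than are shown below. What is called first, only, known or untested is meant among the compounds shown, and "the series" means these compounds.

In an assay on HEK293 cells for inhibition of solute carrier family 22 member 12 (Homo sapiens) (on this read-out higher numbers stand for weaker inhibition and lower numbers for stronger inhibition), compound 1 `O=C(O)CSc1nnc(Br)n1Cc1ccc(Br)c2ccccc12` gives 94 nM, compound 2 `Oc1c(Br)cc(CSc2nnc(Br)n2Cc2ccc(Br)c3ccccc23)cc1Br` gives 119000 nM and compound 3 `O=S(=O)(CSc1nnc(Br)n1Cc1ccc(Br)c2ccccc12)Nc1ccccc1` gives 15800 nM. Compound 3 thus stands second highest of the three numbers, nearer to compound 2 than to compound 1: a 7.5-fold lower number from compound 2 to compound 3 (0.88 log units; beyond the scatter), whereas a 170-fold higher number from compound 1 to compound 3 (2.23 log units; beyond the scatter) and a 1300-fold higher number from compound 1 to compound 2 (3.10 log units; beyond the scatter). Compound 4 `O=S(=O)(CSc1nnc(Br)n1Cc1ccc(Br)c2ccccc12)Nc1cncc(C(F)(F)F)c1` differs from compound 3 only at the sulfonamide nitrogen: 5-(trifluoromethyl)pyridin-3-yl in place of phenyl on a sulfonamide nitrogen. Among the compounds with values here, none of the measured steps touches this position; all three vary the group on the saturated chain carbon bound to sulfur, so the data give no direct guide. No step beyond the scatter is therefore expected in this assay in either direction, and compound 4 is estimated at 15000 nM (range 4000 nM to 60000 nM), an expected step of a 1.1-fold lower number from compound 3 to compound 4 (0.02 log units; within the scatter).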

Compound 4, half-maximal inhibitory concentration: 6380 nM
Compound 4: middle estimate off by 2.4-fold (0.37 log units), on the high side, and the stated range covers the measured number.
By their numbers in this assay, from the lowest: compound 1; then compound 4; then compound 3; then compound 2.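

In this assay the sulfonamide nitrogen proves responsive, since 5-(trifluoromethyl)pyridin-3-yl in place of phenyl gives a 2.5-fold lower number from compound 3 to compound 4 (0.39 log units; beyond the scatter) as a modest step. Within the data shown here, this is the first reading at this nitrogen, and the change brings in the ring nitrogen and the trifluoromethyl together. No measured property accounts for the step.

Still open is which of the two carries the step, as plain pyridin-3-yl and a phenyl bearing trifluoromethyl are not among the compounds shown. Also open, on these data alone, is how a carboxylic acid or an amine on this ring would read.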